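This account rests on a few compounds, and the source may have more. Where it says the series, first, only, none or still open, it means among the compounds named here.

Measured so far in a functional assay on MCF7 cells (Homo sapiens) for inhibition, read by MTT assay, with a stated time of 72 h; a lower number here means a stronger inhibitor of growth, a higher number a weaker inhibitor of growth:
- compound 1, `CC(C)(C)c1ccc(CNCCCNS(=O)(=O)c2cc(C(F)(F)F)cc(C(F)(F)F)c2)cc1`: 2100 nM
- compound 2, `COc1cccc(CNCCCNS(=O)(=O)c2cc(C(F)(F)F)cc(C(F)(F)F)c2)c1`: 2400 nM
- compound 3, `O=S(=O)(NCCCNCc1ccc(C(F)(F)F)cc1)c1cc(C(F)(F)F)cc(C(F)(F)F)c1`: 1400 nM

The three compounds share one core and differ only in the aromatic group carried on the saturated chain carbon bound to the amine nitrogen. Compound 2 gives the nominally highest of the three numbers, but the steps of a 1.1-fold higher number from compound 1 to compound 2 (0.06 log units; within the scatter) and a 1.7-fold lower number from compound 2 to compound 3 (0.23 log units; within the scatter) both lie within the scatter, as does a 1.5-fold lower number from compound 1 to compound 3 (0.18 log units; within the scatter); on the numbers shown the three cannot be told apart.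

Compound 4, `CN(CCCNS(=O)(=O)c1cc(C(F)(F)F)cc(C(F)(F)F)c1)Cc1ccccc1`, has not yet been measured. It differs from compound 2 in one place: benzyl(methyl)amino in place of (3-methoxybenzyl)amino on a saturated chain carbon, three bonds along the chain from a sulfonamide nitrogen. The group entering, benzyl(methyl)amino, carries 0 hydrogen-bond donors where the (3-methoxybenzyl)amino group leaving carried 1.

Within the data shown here, the steps that bear on this change are those that vary the same benzyl position, a 1.1-fold higher number from compound 1 to compound 2 (0.06 log units; within the scatter) and a 1.7-fold lower number from compound 2 to compound 3 (0.23 log units; within the scatter); neither moved beyond the scatter. Among the measured compounds shown here, no measured step varies the amine nitrogen itself, so the effect of the methyl there is not covered. The step expected is no change at the digits printed from compound 2 to compound 4 (within the scatter), that is, none beyond the scatter. For compound 4 the estimate in this assay is 2400 nM, with a range from 1100 nM to 5500 nM.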

Compound 4, concentration for 50% growth inhibition: 16000 nM
The estimate for compound 4 lay 6.7-fold (0.82 log units) below the measured number, outside the stated range (above it).
By their numbers in this assay, from the lowest: compounds 3, 1 and 2 (each within the scatter of the next); then compound 4.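

In this assay, among these compounds, putting benzyl(methyl)amino in place of (3-methoxybenzyl)amino gives a 6.7-fold higher number from compound 2 to compound 4 (0.82 log units; beyond the scatter), the only step so far that lies beyond the scatter. Changes to the aromatic group alone among compounds 1, 2 and 3 left the number within the scatter, so this position responds to a change that includes the amine nitrogen, a response those compounds could not reveal. No available data explain this step.

The change removes the methoxy group and adds the methyl on the amine nitrogen at once, so the compounds shown do not separate the two contributions; an unsubstituted benzylamino group would do so. Also open, as far as these compounds go, is whether a larger group on that nitrogen, such as ethyl, or an amide in place of the amine follows compound 4.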